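Amide ring swap in an azetidine oxadiazole series

A few compounds are considered here, and "the series" means these few. Any claim that something is new, unique, unknown or untested is made for them only; others in the source may bear on it.

compound 1: `O=C(C1CCC2(CCC2)CC1)N1CC(c2nc(-c3cccc(Cl)c3)no2)C1`, 1100 nM
compound 2: `COC1CCN(C(=O)N2CC(c3nc(-c4cccc(Cl)c4)no3)C2)CC1`, > 10000 nM

In an assay on HEK293 cells for positive allosteric modulation of metabotropic glutamate receptor 5 (Homo sapiens), read by FLIPR (on this read-out lower numbers stand for an effect already at smaller amounts and higher numbers for an effect only at larger amounts of compound), compound 1 gives 1100 nM. Compound 2 reaches only the assay limit, > 10000 nM, and its place is known only as the limit of > 10000 nM in this assay, at which 1 of the 2 values shown sits. Going by the values given here, the single measured step, an at least 9.0-fold higher number from compound 1 to compound 2 (0.95 log units; beyond the scatter), was a loss. Compound 3, `CC1CN(C(=O)N2CC(c3nc(-c4cccc(Cl)c4)no3)C2)CC(C)O1`, carries 2,6-dimethylmorpholin-4-yl in place of 4-methoxypiperidin-1-yl on a carbonyl carbon. Since compound 2 sits at the limit, the step that the limit leaves unreadable from compound 2 to compound 3 is expected to be none beyond the scatter, with compound 3 estimated at 12000 nM, within 3000 nM to 50000 nM.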

Compound 3, half-maximal effective concentration: > 10000 nM
Compound 3: no number, only a limit; the forecaster's own chance of this, stated with the estimate: 70%; the middle value does not contradict the limit.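

Putting 2,6-dimethylmorpholin-4-yl on the carbonyl carbon gives an at least 9.0-fold higher number from compound 1 to compound 3 (0.95 log units; beyond the scatter) in this assay, so a second group joined through its ring nitrogen, after 4-methoxypiperidin-1-yl, also fails to keep the value of compound 1. Compound 3 stands at a limit and not at a number, and the step between compound 2 and compound 3 cannot be read: the limit of > 10000 nM in this assay, at which 2 of the 3 values shown sit.

The compounds shown leave open what number compound 2 or compound 3 would have. They also leave open whether a dimethylamino group or an open alkyl chain on the carbonyl carbon would give a measurable value.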